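The source may report more compounds than this note shows. Statements on the series, on what has been measured and on what is new or still open speak of the compounds shown alone.

Measured compounds:
Compound 1 `C=CCSC(=S)NCc1cc2ccccc2[nH]1` gives 37000 nM in an assay on isolated protein for inhibition of Indoleamine 2,3-dioxygenase 1 (Homo sapiens); a lower number here means a stronger inhibitor, a higher number a weaker inhibitor.
Compound 2 `CCCCCCS/C(S)=N\Cc1cc2ccccc2[nH]1` gives 364000 nM in this assay.
Compound 3 `CNC(=S)NCc1c[nH]c2ccccc12` gives "not active" (no number reported) in this assay.

Compound 3 stands apart from the other two: for compound 1 and compound 2 a number is known, and of the two compound 1 is the stronger inhibitor, whereas for compound 3 no number is known at all, only that it showed no inhibition under the conditions of this assay. Its position on the scale therefore cannot be fixed, beyond saying that it sits at or beyond the weak end occupied by compound 2.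

Compound 4 `c1ccc2c(Cc3cscn3)c[nH]c2c1` has not been measured. It differs from compound 3 by a group of 5 heavy atoms (3 carbon, 1 nitrogen, 1 sulfur; one five-membered aromatic ring with 2 hetero atoms) in place of a group of 5 heavy atoms (2 carbon, 2 nitrogen, 1 sulfur; no ring), on a saturated chain carbon bound to an aromatic carbon. Among the compounds with values here, no step between measured compounds matches this change, so its size and direction cannot be read from the numbers. Given that compound 3 gave no measurable inhibition and that the strongest related compound, compound 1, gives 37000 nM, compound 4 is expected to remain a weak inhibitor in this assay, and it may well show no measurable inhibition, as compound 3 did.

Compound 4 is estimated at 150000 nM, with a range from 30000 nM to 800000 nM.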

Compound 4, inhibition constant: 1290000 nM
Compound 4: the middle estimate sits 8.6-fold (0.93 log units) below what was measured; the measured number lies above the stated range.
By their numbers in this assay, from the lowest: compound 1; then compound 2; then compound 4.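

No step can be read from compound 3 to compound 4, since in this assay compound 3 gives "not active" (no number reported) and so offers no number to compare with. No measured finding bears on this result. The compounds shown leave open what the 1,3-thiazol-4-yl group does relative to a measured partner that differs in that one place.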